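Adding a second methoxy group to compound 2

The source may report more compounds than this note shows. Statements on the series, on what has been measured and on what is new or still open speak of the compounds shown alone.

- Compound 1 `COc1ccccc1/C=C1\CCC/C(=C\c2cccc(OC)c2OC)C1=O` gives 31300 nM
- Compound 2 `COc1ccc(/C=C2\CCC/C(=C\c3cccc(OC)c3OC)C2=O)cc1` gives 43500 nM

Going by the values given here, in an ADME assay on NHDF cells (Homo sapiens) for cytotoxicity, read by MTT assay, with a stated time of 72 h (a higher number here means a weaker inhibitor, a lower number a stronger inhibitor), only two numbers exist so far, and compound 2 at 43500 nM cannot be told apart from compound 1 at 31300 nM. Compound 3 `COc1ccc(/C=C2\CCC/C(=C\c3cccc(OC)c3OC)C2=O)c(OC)c1` is compound 2 with one change: methoxy in place of hydrogen on an aromatic carbon, ortho to a large group and meta to a methoxy group (methoxy in place of hydrogen on an aromatic carbon). Among the compounds with values here, no measured step adds a methoxy group, so the evidence is indirect. Within the data shown here, the only measured step is a 1.4-fold higher number from compound 1 to compound 2 (0.14 log units; within the scatter), which swaps a 2-methoxyphenyl for a 4-methoxyphenyl and stays within the scatter. Compound 3 carries the methoxy groups of both earlier compounds on that ring, so no clear shift in either direction is expected in this assay. The expected change is a 1.2-fold lower number from compound 2 to compound 3 (0.09 log units; within the scatter). For compound 3 the estimated value is 35000 nM, with an expected range from 15000 nM to 75000 nM.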

Compound 3, half-maximal inhibitory concentration: > 50000 nM
Compound 3 ended at the assay's limit; the forecaster's own chance of this, stated with the estimate: 10%; at least 1.4-fold (0.15 log units) between middle value and limit.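

In this assay compound 3 gives > 50000 nM, which is a limit of the assay and not a number. Methoxy in place of hydrogen on this aromatic carbon, ortho to a large group and meta to a methoxy group, gives an at least 1.1-fold higher number from compound 2 to compound 3 (0.06 log units; that floor lies within the scatter), while the comparison with the other earlier compound gives an at least 1.5-fold higher number from compound 1 to compound 3 (0.20 log units; that floor lies within the scatter). The earlier compounds shown here only showed a methoxy group in two different places, whereas this result shows that carrying both on the ring does not bring the number down, although both floors lie within the scatter and no real rise is proven.

As far as these compounds go, how far the number truly lies beyond the limit stays unknown. From the compounds shown here alone, it is also open how an amine, a hydroxyl group or a carboxylic acid would behave on this same aromatic carbon.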